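Swapping the benzyloxy for an amino group

The source may hold more compounds than are shown below. What is called first, only, known or untested is meant among the compounds shown, and "the series" means these compounds.

Compound 3 `O=C(/C=C/c1ccc2c(c1)B(O)OC2)c1ccc(OCc2ccccc2)cc1` shares its core with compound 1 `O=C(/C=C/c1ccc2c(c1)B(O)OC2)c1cccs1` and compound 2 `Cn1cccc1C(=O)/C=C/c1ccc2c(c1)B(O)OC2`, differing only in the group attached to the carbonyl carbon. In a functional assay on MDA-MB-231 cells (Homo sapiens) for cytotoxicity, read by MTT assay, with a stated time of 48 h (on this read-out lower numbers stand for stronger inhibition and higher numbers for weaker inhibition), compound 1 gives 4600 nM and compound 3 gives 5300 nM, the two numbers sitting within the scatter of each other, with compound 3 the higher of the two numbers shown. For compound 2 the assay reports only a limit, > 100000 nM, so the shift an at least 21-fold higher number from compound 1 to compound 2 (1.33 log units; beyond the scatter) is known only as a lower bound (the limit of > 100000 nM in this assay, at which 1 of the 3 values shown sits). Compound 4 `Nc1ccc(C(=O)/C=C/c2ccc3c(c2)B(O)OC3)cc1` differs from compound 3 by amino in place of benzyloxy on an aromatic carbon. For the measured compounds named here, no measured step touches this position: the one step recorded alters the aryl group on the carbonyl carbon, not a substituent on an aryl ring that is retained. The expectation therefore rests on compound 3 alone, and a step of a 1.1-fold lower number from compound 3 to compound 4 (0.03 log units; within the scatter) is estimated, with a wide range in either direction. Compound 4 is thus expected to give about 5000 nM in this assay, between 1200 nM and 25000 nM.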

Compound 4, half-maximal inhibitory concentration: 25800 nM
For compound 4 the middle estimate is 5.2-fold (0.71 log units) below the measured one; the whole stated range lies below it.
By their numbers in this assay, from the lowest: compounds 1 and 3 (each within the scatter of the next); then compound 4. At a limit, above all of these: compound 2.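

In this assay, for the compounds shown here, the substituent on the retained aromatic ring proves to matter: amino in place of benzyloxy, on an aromatic carbon para to a large group, gives a 4.9-fold higher number from compound 3 to compound 4 (0.69 log units; beyond the scatter), the only measured step at this position. Setting 4-aminophenyl in place of thiophen-2-yl on the carbonyl carbon gives a 5.6-fold higher number from compound 1 to compound 4 (0.75 log units; beyond the scatter), so this aryl group does not match the thiophen-2-yl group as the 4-benzyloxyphenyl group of the shared series did. Setting 4-aminophenyl in place of 1-methyl-1H-pyrrol-2-yl gives an at least 3.8-fold lower number from compound 2 to compound 4 (0.58 log units; beyond the scatter), a lower bound set by a limit: the limit of > 100000 nM in this assay, at which 1 of the 4 values shown sits.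

The compounds shown cannot separate the loss of the benzyloxy ring from the entry of the amino group. From the compounds shown here alone, how a methoxy or hydroxyl group on this aromatic carbon would read remains open.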